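A few compounds are considered here, and "the series" means these few. Any claim that something is new, unique, unknown or untested is made for them only; others in the source may bear on it.

In a functional assay on Huh-7 cells (Homo sapiens) for inhibition, read by MTT assay, with a stated time of 48 h (on this read-out lower numbers stand for stronger inhibition and higher numbers for weaker inhibition), compound 2 `COc1ccc(CNC(=O)/C=C/c2coc3cc(OC)ccc3c2=O)cc1` gives 7570 nM, the lowest of the three numbers gathered so far, although it lies within the scatter of its two neighbours. Compound 3 `COc1ccc(CNC(=O)/C=C/c2coc3cc(O)ccc3c2=O)cc1` gives 8430 nM, and compound 1 `COc1ccc2c(=O)c(/C=C/C(=O)Nc3cc(C)ccc3C)coc2c1` gives 11100 nM. The step from compound 2 to compound 4 `COc1ccc2c(=O)c(/C=C/C(=O)Nc3ccccc3OC)coc2c1` makes this change: 2-methoxyphenyl in place of 4-methoxybenzyl on an amide-type nitrogen. Within the data shown here, the one measured step that touches the same amide-type nitrogen is a 1.5-fold lower number from compound 1 to compound 2 (0.17 log units; within the scatter), and the other measured step, a 1.1-fold higher number from compound 2 to compound 3 (0.05 log units; within the scatter), sits elsewhere. Neither rose beyond the scatter, so no step beyond the scatter is expected here either, with at most a drift toward the number of compound 1. The estimate for compound 4 is therefore 9500 nM, with a range from 5000 nM to 18000 nM, which means an expected step of a 1.3-fold higher number from compound 2 to compound 4 (0.10 log units; within the scatter).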

Compound 4, half-maximal inhibitory concentration: 32300 nM
Compound 4: the middle estimate sits 3.4-fold (0.53 log units) below what was measured; the measured number lies above the stated range.
By their numbers in this assay, from the lowest: compounds 2, 3 and 1 (each within the scatter of the next); then compound 4.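

With 2-methoxyphenyl on the amide-type nitrogen, inhibition weakens: the change gives a 4.3-fold higher number from compound 2 to compound 4 (0.63 log units; beyond the scatter), and the comparison with the 2,5-dimethylphenyl group gives a 2.9-fold higher number from compound 1 to compound 4 (0.46 log units; beyond the scatter). Among these compounds, the earlier change at this nitrogen, from 2,5-dimethylphenyl to 4-methoxybenzyl, stayed within the scatter, so these are the first steps to show that the group here can alter the read-out, if only modestly. No available evidence explains this loss. Also open, as far as these compounds go, is how an amine or a carboxylic acid on this nitrogen's aromatic ring would read.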